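Sulfonyl aryl variation on a piperidinyl-piperidine sulfonamide core

The source may report more compounds than this note shows. Statements on the series, on what has been measured and on what is new or still open speak of the compounds shown alone.

The series shares the core of compound 1 `CC1CCN(C2CCN(S(=O)(=O)c3ccc(C#N)cc3)CC2)CC1` and varies the aryl group on the sulfonyl sulfur. Within the data shown here, in a functional assay on DLD-1 cells (Homo sapiens) for antiproliferative activity, read by CellTiter-Glo, with a stated time of 72 h (on this read-out lower numbers stand for stronger inhibition and higher numbers for weaker inhibition), compound 1 gives 2800 nM, the highest of the two numbers measured so far. Compound 2 `COc1ccccc1-c1ccc(S(=O)(=O)N2CCC(N3CCC(C)CC3)CC2)cc1` gives 26 nM in this assay, a step of a 110-fold lower number from compound 1 to compound 2 (2.03 log units; beyond the scatter). Compound 3 `Cc1ccc(S(=O)(=O)N2CCC(N3CCC(C)CC3)CC2)cc1C` carries the change (3,4-dimethylphenyl in place of 4-cyanophenyl on a sulfonyl sulfur). Among the measured compounds shown here, no measured step covers this exact change; the only step available is the one from compound 1 to compound 2, in which replacing the cyano on the aromatic carbon by 2-methoxyphenyl produced a large drop in the number. That step bears only loosely on compound 3, since 3,4-dimethylphenyl is not 2-methoxyphenyl. A downward step beyond the scatter is expected, but smaller than a 110-fold lower number from compound 1 to compound 2 (2.03 log units; beyond the scatter). Compound 3 is estimated at 500 nM in this assay, range 100 nM to 2500 nM, an expected step of a 5.6-fold lower number from compound 1 to compound 3 (0.75 log units; beyond the scatter).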

Compound 3, half-maximal inhibitory concentration: 24 nM
The estimate for compound 3 lay 21-fold (1.32 log units) above the measured number; the whole stated range lies above it.
By their numbers in this assay, from the lowest: compounds 3 and 2 (each within the scatter of the next); then compound 1.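

Replacing 4-cyanophenyl with 3,4-dimethylphenyl on the sulfonyl sulfur gives a 120-fold lower number from compound 1 to compound 3 (2.07 log units; beyond the scatter), so a large step at this position does not depend on a biaryl group such as that of compound 2. Compound 2 at 26 nM and compound 3 at 24 nM lie within the scatter of each other, although the two groups share only the benzene ring bonded to the sulfonyl sulfur. No independent evidence bears on why either group gives so much lower a number than 4-cyanophenyl.

The compounds shown leave open whether the step comes from losing the nitrile or from gaining the two methyl groups. Unsubstituted phenyl, a single methyl group and a carboxylic acid on the ring would help separate these readings.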